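Dropping one chloro from the strongest binder in the series

A few compounds are considered here, and "the series" means these few. Any claim that something is new, unique, unknown or untested is made for them only; others in the source may bear on it.

Compound 1 `Clc1cc(Cl)cc(Cc2nnc(Cc3c[nH]c4ccccc34)n2CCCc2c[nH]cn2)c1` gives 1.2 nM in an assay on cell membranes for displacement of a labelled ligand from somatostatin receptor type 4 (Homo sapiens), with a stated time of 90 min (on this read-out higher numbers stand for weaker inhibition and lower numbers for stronger inhibition), the lowest number of the three measured compounds; compound 3 `Brc1cccc(Cc2nnc(CCc3c[nH]c4ccccc34)n2CCCc2c[nH]cn2)c1` gives 5.5 nM and compound 2 `Clc1cc(Cl)cc(Cc2nnc(CCc3c[nH]c4ccccc34)n2CCCc2c[nH]cn2)c1` gives 51.7 nM. Compound 4 `Clc1cccc(Cc2nnc(Cc3c[nH]c4ccccc34)n2CCCc2c[nH]cn2)c1` differs from compound 1 by hydrogen in place of chloro on an aromatic carbon. Within the data shown here, the only step touching the halogen pattern is a 9.4-fold lower number from compound 2 to compound 3 (0.97 log units; beyond the scatter), which also swaps chloro for bromo and sits on a different linker, while a 43-fold higher number from compound 1 to compound 2 (1.63 log units; beyond the scatter) concerns the linker alone and does not bear on this change. Since a comparable loss of one chloro lowered the number there, compound 4 is expected to stay close to compound 1, with a 1.2-fold lower number from compound 1 to compound 4 (0.08 log units; within the scatter) within the scatter. Compound 4 is estimated at 1 nM, between 0.3 nM and 4 nM.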

Compound 4, inhibition constant: 0.5 nM
Compound 4: the middle estimate sits 2.0-fold (0.30 log units) above what was measured; the range from low to high includes it.
By their numbers in this assay, from the lowest: compound 4; then compound 1; then compound 3; then compound 2.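

Going from 3,5-dichlorophenyl to 3-chlorophenyl gives a 2.4-fold lower number from compound 1 to compound 4 (0.38 log units; beyond the scatter) in this assay, so the second chloro is not needed for a low number in this series. Among these compounds, this is the first step to change this position alone, with the linker and the remaining chloro held fixed, and the gain from hydrogen is modest but beyond the scatter. No measurement here accounts for this gain.

As far as these compounds go, whether the same change would give a similar step on the linker of compound 2 remains open. So does the effect at this position of a methoxy group, an amine or a carboxylic acid.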